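Swapping Nitro for Methyl: An Expected Antiproliferative Step

A few compounds are considered here, and "the series" means these few. Any claim that something is new, unique, unknown or untested is made for them only; others in the source may bear on it.

Three compounds were tested in a functional assay on HepG2 cells (Homo sapiens) for antiproliferative activity, tested at 1 uM; on this read-out higher numbers stand for more inhibition at the one concentration tested (going by the name of the read-out) and lower numbers for less inhibition. Compound 1 `Cc1ccc(CO/N=C/c2c(C)nn(C)c2Oc2ccc(Cl)cc2)cc1` gives 31.3%, compound 2 `Cc1nn(C)c(Oc2ccc(Cl)cc2)c1/C=N/OCc1ccc([N+](=O)[O-])cc1` gives 18.4%, and compound 3 `Cc1nn(C)c(Oc2ccccc2)c1/C=N/OCc1ccc([N+](=O)[O-])cc1` gives -2.8%, the lowest of the three. Two single changes connect them. From compound 2 to compound 1 the change is methyl in place of nitro on an aromatic carbon, and in this assay it brings a number 12.9 percentage points higher from compound 2 to compound 1 (beyond the scatter). From compound 2 to compound 3 the change is hydrogen in place of chloro on an aromatic carbon, which brings a number 21.2 percentage points lower from compound 2 to compound 3 (beyond the scatter).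

Compound 4 `Cc1ccc(CO/N=C/c2c(C)nn(C)c2Oc2ccccc2)cc1` has not yet been measured. It differs from compound 3 by methyl in place of nitro on an aromatic carbon, the same change at the same place that separates compound 1 from compound 2; the two cores differ only by the change just described from compound 2 to compound 3. With one measured example of this change, the expected step for compound 4 in this assay is a number 12.8 percentage points higher from compound 3 to compound 4 (beyond the scatter), set beside the earlier one because that single pair showed a number 12.9 percentage points higher from compound 2 to compound 1 (beyond the scatter). Compound 4 is therefore estimated at 10%, with a range from -5% to 25%, the width reflecting that the expectation rests on one pair alone.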

Compound 4, a percentage reported as inhibition, at one concentration (the size of the read-out at that concentration, not a potency): 8.4%
For compound 4 the middle estimate is 1.6 percentage points above the measured one; low and high end bracket the measured number.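

Methyl in place of nitro brings a number 11.2 percentage points higher from compound 3 to compound 4 (beyond the scatter) in this assay, so the change carries from the core of compound 2 to the core of compound 3 at much the same size: the same change on two cores in this assay, a number 12.9 percentage points higher (beyond the scatter) from compound 2 to compound 1 and a number 11.2 percentage points higher (beyond the scatter) from compound 3 to compound 4, 1.7 percentage points apart, within the scatter of two such steps

Read the other way round, hydrogen in place of chloro brings a number 22.9 percentage points lower from compound 1 to compound 4 (beyond the scatter), and it does so with methyl on the aromatic ring much as it did with nitro: the same change on two cores in this assay, a number 21.2 percentage points lower (beyond the scatter) from compound 2 to compound 3 and a number 22.9 percentage points lower (beyond the scatter) from compound 1 to compound 4, 1.7 percentage points apart, within the scatter of two such steps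

Within the data shown here, the four compounds therefore show the two changes adding up without visible interference, but they show this for only two cores, at one concentration and in one cell line, and they do not show why either change moves the number or whether it would hold on any other core.

Left open is what an amine or a carboxylic acid on the same aromatic carbon would give in this assay. As far as these compounds go, it is also open whether bromo in place of chloro would bring a step like the one seen for chloro.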